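Triazene series: tolerated concentration on MT4 cells, compounds 1 to 4

This account rests on a few compounds, and the source may have more. Where it says the series, first, only, none or still open, it means among the compounds named here.

Measured in an ADME assay on MT4 cells (Homo sapiens) for cytotoxicity, read by MTT assay, with a stated time of 96 h (a higher number here means that more compound is tolerated, a lower number that less compound is tolerated), so far:
- compound 1 `Clc1cccc(/N=N/N2CCCCC2)c1`: a limit only, > 100000 nM
- compound 2 `c1ccc(/N=N/N2CCCCC2)cc1`: a limit only, > 100000 nM
- compound 3 `Clc1ccc(/N=N/N2CCCC2)cc1`: a limit only, > 100000 nM

All three values are limits of this assay and not numbers. This is summed up by the limit of > 100000 nM in this assay, at which 3 of the 3 values shown sit. For the measured compounds named here, the one step that can be paired up, a step that the two limits leave unreadable from compound 2 to compound 1, cannot be read as a size, because both ends of it are limits. The change behind that step is chloro in place of hydrogen on an aromatic carbon.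

Compound 4 `Clc1ccc(/N=N/N2CCCC2)cc1Cl` has not yet been measured in this assay. It is reached from compound 3 by chloro in place of hydrogen on an aromatic carbon. Going by the values given here, this is the same kind of change as the one from compound 2 to compound 1, but the surroundings differ: in compound 1 the entering chloro sits meta to a group of 8 heavy atoms, whereas in compound 4 it sits ortho to a chloro group (1 heavy atom) and meta to a group of 7 heavy atoms. The difference between the cores of compound 2 and compound 3 is not broken down here.

Since every value shown sits at the limit described by the limit of > 100000 nM in this assay, at which 3 of the 3 values shown sit, and the parent compound 3 gives > 100000 nM, compound 4 is expected to give 100000 nM, between 30000 nM and 300000 nM. The step this estimate implies, a number no higher from compound 3 to compound 4 (the limit leaves the size open), is expected to be flat, most likely again ending at the limit of this assay.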

Compound 4, half-maximal cytotoxic concentration: 75000 nM
For compound 4 the middle estimate is 1.3-fold (0.12 log units) above the measured one; low and high end bracket the measured number.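

In this assay, chloro in place of hydrogen on an aromatic carbon, here ortho to a chloro group and meta to a group of 7 heavy atoms, comes with an at least 1.3-fold lower number from compound 3 to compound 4 (0.12 log units; that floor lies within the scatter). For the compounds shown here, this is the only readable trace of the change, and its full size stays open because the starting end of the step is a limit of the assay rather than a number: the limit of > 100000 nM in this assay, at which 3 of the 4 values shown sit. The step from compound 2 to compound 1 cannot be read, so the two cores offer no pair of sizes to set side by side, the entering chloro has different surroundings in compound 1 and compound 4, and nothing here shows that the change carries from one core to the other with the same effect, or that it fails to.

The compounds shown leave open whether the number found for compound 4 is particular to chloro or would also appear with another group on the aromatic ring, such as a methoxy group, an amine or a carboxylic acid. They also leave open what a second chloro would do on the core of compound 1.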